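A Fluoro for Chloro Exchange in Compound 3

The source may hold more compounds than are shown below. What is called first, only, known or untested is meant among the compounds shown, and "the series" means these compounds.

In an ADME assay on L6 cells (Rattus norvegicus) for cytotoxicity, read by resazurin assay, with a stated time of 72 h (on this read-out lower numbers stand for stronger inhibition and higher numbers for weaker inhibition), compound 1 (`O=[N+]([O-])c1cn2c(n1)OC[C@H](OCc1ccc(-c3ccc(OC(F)(F)F)cc3Cl)cc1)C2`) reads 25000 nM on this scale. Compound 2 (`CC1(COc2ccc(OC(F)(F)F)c(Cl)c2)CCn2cc([N+](=O)[O-])nc2O1`) reads 53000 nM and so stands highest of the two numbers, beyond the scatter from compound 1. Compound 3 (`CC1(COc2ccc(OC(F)(F)F)c(F)c2)CCn2cc([N+](=O)[O-])nc2O1`) has not yet been measured. It differs from compound 2 in one place (fluoro in place of chloro on an aromatic carbon), with fluoro in place of chloro on an aromatic carbon, ortho to a trifluoromethoxy group. Within the data shown here, no measured pair shows this exchange, so the expectation starts from compound 2 at 53000 nM and stays close to it. In this assay the expected change is a small rise toward weaker inhibition (a 1.2-fold higher number from compound 2 to compound 3 (0.09 log units; within the scatter)), estimated to remain within the scatter. For compound 3 the estimated value is 65000 nM with an expected range from 30000 nM to 140000 nM around it.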

Compound 3, half-maximal inhibitory concentration in the L6 assay: 68000 nM
Beside the measured number, compound 3's estimate is 1.0-fold (0.02 log units) below it; low and high end bracket the measured number.
By their numbers in the L6 assay, from the lowest: compound 1; then compounds 2 and 3 (each within the scatter of the next).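

Fluoro in place of chloro, ortho to a trifluoromethoxy group, gives a direct reading of this position that the earlier compounds did not offer: in the L6 assay the step is a 1.3-fold higher number from compound 2 to compound 3 (0.11 log units; within the scatter), so the two halogens cannot be told apart here. In a physicochemical assay for solubility, read by HPLC, measured as kinetic solubility, with a stated time of 15 min (a lower number here means a less soluble compound, a higher number a more soluble compound), the same exchange gives a 1.9-fold higher number from compound 2 to compound 3 (0.28 log units; within the scatter), with compound 2 at 0.5 ug/mL and compound 3 at 0.95 ug/mL, so here too the two cannot be told apart. Nothing at hand offers an explanation for either result.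

The compounds shown leave open whether a non-halogen group at this position, such as methyl, nitrile or methoxy, would move either number beyond the scatter. They also leave open what an amine or a carboxylic acid in place of the trifluoromethoxy group would do.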